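Pyrrole for Pyrazole on the Imidazoline Aryl Core

This account rests on a few compounds, and the source may have more. Where it says the series, first, only, none or still open, it means among the compounds named here.

Compound 1 `Cn1nccc1-c1ccccc1NCC1=NCCN1` carries a 1-methyl-1H-pyrazol-5-yl group on its shared core. In an in vitro functional assay on cells (Fibroblast) for agonist activity at Alpha-1D adrenergic receptor (Homo sapiens) (a higher number here means that more compound is needed for the effect, a lower number that less compound is needed), compound 1 gives only a limit, < 100000 nM, not a number. Its one measured relative, compound 2 `CC(C)n1nccc1-c1ccccc1NCC1=NCCN1`, differs by isopropyl in place of methyl on an aromatic nitrogen. In this assay compound 2 also gives only a limit, < 100000 nM. Among the measured compounds shown here, the step that the two limits leave unreadable from compound 1 to compound 2 therefore cannot be sized, and all that is known of the series so far is the limit of < 100000 nM in this assay, at which 2 of the 2 values shown sit.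

Compound 3 `Cn1cccc1-c1ccccc1NCC1=NCCN1` is the unmeasured partner of compound 1, and the change is 1-methyl-1H-pyrrol-2-yl in place of 1-methyl-1H-pyrazol-5-yl on an aromatic carbon. No measured step touches this exchange: the single step shown concerns the methyl on the aromatic nitrogen, not the ring itself, and it is unreadable in any case. With no anchor for either direction or size, the step that the limit leaves unreadable from compound 1 to compound 3 is offered only as a guess, centred on no change. Compound 3 is accordingly expected to give about 10000 nM in this assay, with a wide span from 500 nM to 100000 nM, and a strong chance that this assay again returns only a limit.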

Compound 3, half-maximal effective concentration: 251 nM
Compound 3: the middle estimate sits 40-fold (1.60 log units) above what was measured; measured number outside the range, below it.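

Among the compounds shown here, with compound 1 resting only on a limit, no step from compound 1 to compound 3 can be read in this assay, although compound 3 gives a number. The compounds shown leave open how far 1-methyl-1H-pyrrol-2-yl and 1-methyl-1H-pyrazol-5-yl differ on the shared core, and most values still sit at one limit: the limit of < 100000 nM in this assay, at which 2 of the 3 values shown sit.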